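A few compounds are considered here, and "the series" means these few. Any claim that something is new, unique, unknown or untested is made for them only; others in the source may bear on it.

Measured so far:
- Compound 1 `COC(=O)NCC#CCn1cncc1C`: > 100 mg/kg (a limit)
- Compound 2 `COC(=O)N(C)CC#CCn1ccnc1`: 4.5 mg/kg
- Compound 3 `COC(=O)N(C)CC#CCn1cncc1C`: > 100 mg/kg (a limit)

All three were tested in a functional assay on the whole organism for agonist activity, with Mus musculus as the target; a higher number here means that more compound is needed for the effect, a lower number that less compound is needed. Compound 3 gives > 100 mg/kg, which is a limit and not a number. That places it at the limit of > 100 mg/kg in this assay, at which 2 of the 3 values shown sit.

Compound 4 `COC(=O)N(C)C(C)C#CCn1cncc1C` differs from compound 3 by one change: methyl in place of hydrogen on a saturated chain carbon bound to an amide-type nitrogen and a triple-bonded carbon. Among the measured compounds shown here, two measured steps bear on this, and each also adds a methyl, though at another place. With methyl in place of hydrogen on an aromatic carbon, there is an at least 22-fold higher number from compound 2 to compound 3 (1.34 log units; beyond the scatter), so a single methyl can matter greatly in this series. With methyl in place of hydrogen on an amide-type nitrogen, there is a step that the two limits leave unreadable from compound 1 to compound 3. Neither step puts the methyl on the saturated chain carbon, so the size here stays uncertain. Nothing measured suggests a return towards lower numbers, so the step expected in this assay is small: a step that the limit leaves unreadable from compound 3 to compound 4. Compound 4 is estimated at 150 mg/kg, with an expected range from 50 mg/kg to 500 mg/kg, and will probably be reported only as a limit.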

Compound 4, dose for half-maximal effect: > 100 mg/kg
Compound 4: only a limit was reported; the forecaster's own chance of this, stated with the estimate: 85%; the middle value lies beyond the limit too.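

Compound 3 and compound 4 both stand only at a limit in this assay, and no step can be read between them: the limit of > 100 mg/kg in this assay, at which 3 of the 4 values shown sit.

The compounds shown leave open what dose compound 3 and compound 4 really need, and whether the methyl on the saturated chain carbon changes it.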